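This account rests on a few compounds, and the source may have more. Where it says the series, first, only, none or still open, it means among the compounds named here.

Three compounds have been measured in a functional assay on K562 cells (Homo sapiens) for antiproliferative activity, read by CCK-8 assay, with a stated time of 72 h; on this read-out lower numbers stand for stronger inhibition of growth and higher numbers for weaker inhibition of growth:

Compound 1, `CCCNC(=O)c1ccc2c(ccn2-c2ncc3c(n2)N(c2ccn(C)n2)C(CC)C(=O)N3C)c1`, gives 8270 nM.
Compound 2, `CCCNC(=O)c1ccc2c(ccn2-c2ncc3c(n2)N(C2CCCC2)[C@H](CC)C(=O)N3C)c1`, gives 395 nM.
Compound 3, `CCNC(=O)c1ccc2c(ccn2-c2ncc3c(n2)N(c2ccn(C)n2)C(CC)C(=O)N3C)c1`, gives 12800 nM.

Compound 2 stands clearly lowest of the three. The cores of compound 2 and compound 3 differ by more than one change, and that difference is not broken down here. Between compound 3 and compound 1 the only change is methyl in place of hydrogen on a saturated chain carbon, two bonds along the chain from an amide-type nitrogen, and it made a 1.5-fold lower number from compound 3 to compound 1 (0.19 log units; within the scatter).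

Compound 4, `CCCCNC(=O)c1ccc2c(ccn2-c2ncc3c(n2)N(C2CCCC2)[C@H](CC)C(=O)N3C)c1`, is not yet measured. It differs from compound 2 by methyl in place of hydrogen on a saturated chain carbon, three bonds along the chain from an amide-type nitrogen. This is the same kind of change as from compound 3 to compound 1, but the place is not identical: there the methyl enters two bonds along the chain from the amide-type nitrogen, here three bonds along. Because a 1.5-fold lower number from compound 3 to compound 1 (0.19 log units; within the scatter) lay within the scatter, a similarly small step, a 1.2-fold lower number from compound 2 to compound 4 (0.09 log units; within the scatter), is expected. The estimate for compound 4 in this assay is 320 nM, between 130 nM and 800 nM.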

Compound 4, concentration for 50% growth inhibition: 673 nM
Compound 4: the middle estimate sits 2.1-fold (0.32 log units) below what was measured, and the stated range covers the measured number.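

In this assay, the added methyl on the amide chain gave a 1.7-fold higher number from compound 2 to compound 4 (0.23 log units; within the scatter), a step too small to tell apart from repeat-measurement noise. The earlier step on the other core was also small, and the two cannot be told apart: the same change on two cores in this assay, a 1.5-fold lower number (0.19 log units; within the scatter) from compound 3 to compound 1 and a 1.7-fold higher number (0.23 log units; within the scatter) from compound 2 to compound 4, 2.6-fold (0.42 log units) apart, within the scatter of two such steps. Among these compounds, this suggests that the one-carbon extension carries across these two cores without a readable effect, but it rests on only two pairs, the methyl does not enter at an identical place in them, and a small real effect could lie hidden in the scatter.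

The compounds shown leave open what a much longer chain, such as hexyl, would do. They also leave open the effect of an amine or a carboxylic acid on this chain.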